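A few compounds are considered here, and "the series" means these few. Any claim that something is new, unique, unknown or untested is made for them only; others in the source may bear on it.

For the measured compounds named here, compound 2 `CC/C(=C(/c1ccc(/C=C/C(=O)O)cc1)c1ccc2[nH]ncc2c1)c1ccccc1` gives 6 nM in a functional assay on MCF7 cells (Homo sapiens) for cytotoxicity, read by CellTiter-Glo, with a stated time of 5 days (a lower number here means a stronger inhibitor, a higher number a weaker inhibitor), the lowest of the three numbers measured so far. Compound 3 `CC/C(=C(/c1ccc(/C=C/C(=O)O)c(OC)c1)c1ccc2[nH]ncc2c1)c1ccccc1` gives 31 nM, and compound 1 `CC/C(=C(/c1ccc(/C=C/C(=O)O)cc1)c1ccc2[nH]cnc2c1)c1ccccc1` gives 1180 nM. Both measured steps lie beyond the scatter: a 5.2-fold higher number from compound 2 to compound 3 (0.71 log units; beyond the scatter) and a 200-fold lower number from compound 1 to compound 2 (2.29 log units; beyond the scatter). Compound 4 `CC/C(=C(/c1ccc(/C=C/C(=O)O)cc1)c1ccc2[nH]ncc2c1)c1ccc(C#N)cc1Cl` differs from compound 2 in one place: 2-chloro-4-cyanophenyl in place of phenyl on a double-bonded chain carbon bound to a double-bonded chain carbon and a saturated chain carbon. Neither measured step touches this phenyl; both concern other parts of the shared core, so nothing measured bears directly on the change, and no large swing is indicated by the data. The expectation is therefore a small step, within or near the scatter. Compound 4 is estimated at 8 nM, between 3 nM and 25 nM, which means an expected step of a 1.3-fold higher number from compound 2 to compound 4 (0.12 log units; within the scatter).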

Compound 4, half-maximal inhibitory concentration: 4 nM
For compound 4 the middle estimate is 2.0-fold (0.30 log units) above the measured one, within the range that was stated.
By their numbers in this assay, from the lowest: compounds 4 and 2 (each within the scatter of the next); then compound 3; then compound 1.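

Replacing the phenyl on this double-bonded chain carbon with 2-chloro-4-cyanophenyl gives a 1.5-fold lower number from compound 2 to compound 4 (0.18 log units; within the scatter) in this assay. For the compounds shown here, this is the first measured change at this position, and it shows that the ring here can carry both a chlorine and a nitrile while the number stays within the scatter of that of compound 2. No evidence at hand explains this result. Going by these compounds, the chlorine and the nitrile enter together, so what each does alone remains open. On these data alone, how an amine or a trifluoromethyl group on this ring would read also remains open.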